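Ortho-substituted aryl ureas: fluoro to bromo exchange

A few compounds are considered here, and "the series" means these few. Any claim that something is new, unique, unknown or untested is made for them only; others in the source may bear on it.

Measured compounds:
compound 1, `CC(C)c1ccccc1NC(=O)N[C@H](C)c1ccccc1`: 103%
compound 2, `CC(=O)c1ccccc1NC(=O)N[C@H](C)c1ccccc1`: 96%
compound 3, `C[C@@H](NC(=O)Nc1ccccc1F)c1ccccc1`: 97%

The three compounds share one urea core and differ only in the group on an aromatic carbon. In an ADME assay on the whole organism with Oryza sativa as the target, tested at 0.1 uM (a higher number here means a weaker effect of the compound at the concentration tested, a lower number a stronger effect), compound 3 gives 97%, the second highest of the three numbers on the bare figures, with compound 2 nearest (a number 1 percentage points higher from compound 2 to compound 3 (within the scatter)) and compound 1 furthest (a number 6 percentage points lower from compound 1 to compound 3 (within the scatter)). The remaining step, a number 7 percentage points lower from compound 1 to compound 2 (within the scatter), is also within the scatter, so on the present numbers the three compounds are not told apart in this assay.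

Compound 4, `C[C@@H](NC(=O)Nc1ccccc1Br)c1ccccc1`, is not yet measured. It differs from compound 3 by bromo in place of fluoro on an aromatic carbon.

All three measured steps change the group at this same aromatic carbon, and none of them moves this assay beyond the scatter, whether the group entering is acetyl, fluoro or isopropyl. Among the compounds with values here, no step from fluoro to bromo has been measured, and nothing among the measured compounds points to a different outcome for bromo at this position. The expected step is therefore a number 1 percentage points higher from compound 3 to compound 4 (within the scatter), within the scatter.

For compound 4 in this assay the estimate is 98%, expected between 88% and 108%.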

Compound 4, a percentage reported as activity, at one concentration (the size of the read-out at that concentration, not a potency): 99%
The estimate for compound 4 lay 1 percentage points below the measured number, and the stated range covers the measured number.
By their numbers in this assay, from the lowest: compounds 2, 3, 4 and 1 (each within the scatter of the next).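

In this assay, the exchange of bromo for fluoro on this aromatic carbon, ortho to a large group, is now measured directly (a number 2 percentage points higher from compound 3 to compound 4 (within the scatter)), and it does not separate the two groups. Bromo is likewise not told apart from the other two groups tested at this carbon, acetyl (a number 3 percentage points higher from compound 2 to compound 4 (within the scatter)) and isopropyl (a number 4 percentage points lower from compound 1 to compound 4 (within the scatter)), so the four compounds now form a single group in this read-out at the one concentration tested, with every step among them within the scatter. No measurement at hand bears on why this position tolerates these exchanges without a clear change in the number.

As far as these compounds go, whether a group of another kind on this carbon, such as an amine, a carboxylic acid or a longer chain, would move the number beyond the scatter remains open. Also open are the effects of changes elsewhere in the shared core and of moving bromo to another carbon of the same aromatic ring, since every compound shown carries its varied group at this one place.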